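Chloro for Trifluoromethyl on Two Different Cores

A few compounds are considered here, and "the series" means these few. Any claim that something is new, unique, unknown or untested is made for them only; others in the source may bear on it.

Compound 1 `CCCN1CCC(CNCc2cn(-c3ccc(C(F)(F)F)cc3)nc2-c2ccc(C(F)(F)F)cc2)CC1` and compound 2 `CCCN1CCC(CNCc2cn(-c3ccc(C(F)(F)F)cc3)nc2-c2ccc(Cl)cc2)CC1` share one core and differ by chloro in place of trifluoromethyl on an aromatic carbon. In an ADME assay on Huh-7 cells (Homo sapiens) for cytotoxicity (a higher number here means that more compound is tolerated, a lower number that less compound is tolerated), compound 1 gives 1200 nM and compound 2 gives 1900 nM, a step of a 1.6-fold higher number from compound 1 to compound 2 (0.20 log units; within the scatter). Compound 3 `Cc1ccccc1-c1nn(-c2cccc(C(F)(F)F)c2)cc1CNCCN1CCN(C)CC1` is built on another core; the difference between the two cores is not broken down here. In this assay compound 3 gives 18000 nM, the highest of the three numbers. Compound 4 `Cc1ccccc1-c1nn(-c2cccc(Cl)c2)cc1CNCCN1CCN(C)CC1` is not yet measured and differs from compound 3 by chloro in place of trifluoromethyl on an aromatic carbon. The surroundings are not identical: from compound 1 to compound 2 the group sits para to a large group, from compound 3 to compound 4 it sits meta to a large group, so this is the same kind of change rather than the same change. Because the step of a 1.6-fold higher number from compound 1 to compound 2 (0.20 log units; within the scatter) stayed within the scatter, a step of about the same size is expected for compound 4: a 1.2-fold higher number from compound 3 to compound 4 (0.09 log units; within the scatter). For compound 4 the expected value in this assay is 22000 nM, within a range of 9000 nM to 50000 nM. This expectation rests on a single earlier step made on a different core.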

Compound 4, half-maximal cytotoxic concentration: 16000 nM
For compound 4 the middle estimate is 1.4-fold (0.14 log units) above the measured one; the range from low to high includes it.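

In this assay, putting chloro in place of trifluoromethyl gave a 1.1-fold lower number from compound 3 to compound 4 (0.05 log units; within the scatter), so on this second core, as on the first, the swap produced no difference that can be told apart from ordinary repeat-to-repeat variation. Set side by side, the two steps agree as far as measurements of this kind can tell: the same change on two cores in this assay, a 1.6-fold higher number (0.20 log units; within the scatter) from compound 1 to compound 2 and a 1.1-fold lower number (0.05 log units; within the scatter) from compound 3 to compound 4, 1.8-fold (0.25 log units) apart, within the scatter of two such steps. This suggests that in this assay the swap carried over between these two cores, but it rests on just two pairs in which the group also sits at different places on the ring, so it is no rule for the whole series and says nothing about any other measurement.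

The compounds shown leave open whether other groups at this place, such as a nitrile or a methoxy, would also leave the tolerated concentration where it is on either core. As far as these compounds go, whether the chloro-for-trifluoromethyl swap would behave the same way on a third core also remains open.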